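Pyrrolidine nitrogen substituent: acyl replaced by alkyl

A few compounds are considered here, and "the series" means these few. Any claim that something is new, unique, unknown or untested is made for them only; others in the source may bear on it.

Compound 3 `CC(C)(C)CC(=O)N1CCC[C@H]1C(=O)N1CCC(NS(=O)(=O)c2cc(S(=O)(=O)c3ccccc3)ccc2C(F)(F)F)CC1` is the reference point for this step. Within the data shown here, in a functional assay on U2OS cells for antagonist activity at proto-oncogene Wnt-3 (Homo sapiens), read by a luciferase reporter, with a stated time of 18 h (on this read-out higher numbers stand for an effect only at larger amounts of compound and lower numbers for an effect already at smaller amounts), compound 3 gives 120 nM, which is the second highest of the three numbers measured so far. Compound 1 `CC(C)(C)OC(=O)N1C(=O)CC[C@H]1C(=O)N1CCC(NS(=O)(=O)c2cc(S(=O)(=O)c3ccccc3)ccc2C(F)(F)F)CC1` gives 90 nM in this assay and compound 2 `O=C1CC[C@@H](C(=O)N2CCC(NS(=O)(=O)c3cc(S(=O)(=O)c4ccccc4)ccc3C(F)(F)F)CC2)N1` gives 240 nM; compound 3 sits within the usual scatter of both, nearest to compound 1 and furthest from compound 2.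

Compound 4 `CC(C)(C)CCN1CCC[C@H]1C(=O)N1CCC(NS(=O)(=O)c2cc(S(=O)(=O)c3ccccc3)ccc2C(F)(F)F)CC1` differs from compound 3 in one place: 3,3-dimethylbutyl in place of neopentylcarbonyl on an amine nitrogen in a ring. The acyl group on the ring nitrogen is thus exchanged for an alkyl chain of the same skeleton, the carbonyl dropping out.

Among the measured compounds shown here, no measured pair shows exactly this exchange. The two steps that touch the same ring nitrogen are a 2.7-fold higher number from compound 1 to compound 2 (0.43 log units; beyond the scatter) and a 2.0-fold lower number from compound 2 to compound 3 (0.30 log units; within the scatter). Both concern what stands on that nitrogen and both stay small; the first modest, the second within the scatter. Carbonyl-bearing and hydrogen-bearing variants of this nitrogen therefore all fall within a narrow band, and an alkyl variant is expected to stay near that band rather than leave it.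

Compound 4 is therefore expected to give about 160 nM in this assay, within 50 nM to 500 nM, the expected step being a 1.3-fold higher number from compound 3 to compound 4 (0.12 log units; within the scatter).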

Compound 4, half-maximal effective concentration: 450 nM
Beside the measured number, compound 4's estimate is 2.8-fold (0.45 log units) below it; measured number inside the range.
By their numbers in this assay, from the lowest: compounds 1, 3, 2 and 4 (each within the scatter of the next, the first and the last beyond it).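

Notes on the ring nitrogen: in this assay, exchanging neopentylcarbonyl for 3,3-dimethylbutyl gives a 3.8-fold higher number from compound 3 to compound 4 (0.57 log units; beyond the scatter), so this amine nitrogen in a ring does respond to what it carries, and dropping the carbonyl while keeping the six carbons of the chain is enough to take the step beyond the scatter. The step of a 1.9-fold higher number from compound 2 to compound 4 (0.27 log units; within the scatter) stays within the scatter, so the compounds shown do not separate the 1-(3,3-dimethylbutyl)pyrrolidin-2-yl and 5-oxopyrrolidin-2-yl groups on this carbonyl carbon, and the cost of the alkyl chain appears only against the acylated partner. Nothing available bears on the reason for the step from the acyl to the alkyl group.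

Open, on these data alone, is whether the carbonyl alone carries this difference, which a smaller acyl group such as acetyl, a urea or a sulfonamide on the same nitrogen would help to test. Also open, as far as these compounds go, is how this nitrogen tolerates other alkyl groups, such as a shorter chain, a longer chain, or a chain ending in a hydroxyl group or a carboxylic acid.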